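The source may hold more compounds than are shown below. What is called first, only, known or untested is meant among the compounds shown, and "the series" means these compounds.

Series notes. Compound 1 `COc1ccc(Oc2ccc3cc(NC(=O)c4ccc(OC(C)=O)c(CC=C(C)C)c4)c(=O)oc3c2C)cc1` gives 19500 nM in a functional assay on SK-BR-3 cells (Homo sapiens) for antiproliferative activity; on this read-out higher numbers stand for weaker inhibition and lower numbers for stronger inhibition. Compound 2 `CC(=O)Oc1ccc(C(=O)Nc2cc3ccc(Oc4ccc(C(C)(C)C)cc4)c(C)c3oc2=O)cc1CC=C(C)C` gives 72400 nM in this assay. For the measured compounds named here, the only single-point step measured so far, tert-butyl in place of methoxy on an aromatic carbon, runs a 3.7-fold higher number from compound 1 to compound 2 (0.57 log units; beyond the scatter). Compound 3 `COc1ccc(Oc2ccc3cc(NC(=O)c4ccc(OC)c(-c5cccc(OC)c5)c4)c(=O)oc3c2C)cc1` keeps the 4-methoxyphenoxy group of compound 1 with a different amide portion. In this assay compound 3 reaches only a limit, > 100000 nM, so it stands at the limit of > 100000 nM in this assay, at which 1 of the 3 values shown sits, rather than at a number.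

Compound 4 `COc1ccc(Nc2ccc3cc(NC(=O)c4ccc(OC)c(-c5cccc(OC)c5)c4)c(=O)oc3c2C)cc1` differs from compound 3 in one place: (4-methoxyphenyl)amino in place of 4-methoxyphenoxy on an aromatic carbon. Going by the values given here, none of the measured steps concerns the group exchanged here; the step from compound 1 to compound 2 alters a substituent on an outer ring and gives no guidance on this exchange. Among the compounds with values here, with no step to lean on and compound 3 sitting at a limit, the expectation is for no change beyond the scatter, and a further limit is the likeliest outcome. The step expected here is a number no higher from compound 3 to compound 4 (the limit leaves the size open). Compound 4 is therefore estimated at 100000 nM in this assay, with a range from 30000 nM to 300000 nM.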

Compound 4, half-maximal inhibitory concentration: > 100000 nM
Compound 4 gave a limit, no number; the forecaster's own chance of this, stated with the estimate: 60%; the middle value sits exactly at the limit.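

Compound 3 and compound 4 each give only a limit in this assay, not a number, so no step between them can be read: the limit of > 100000 nM in this assay, at which 2 of the 4 values shown sit.

The compounds shown leave open whether (4-methoxyphenyl)amino in place of 4-methoxyphenoxy changes the read-out at all, including on a compound with a measured number such as compound 1.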